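Cytotoxicity notes: methyl in place of methoxy at compound 4

This account rests on a few compounds, and the source may have more. Where it says the series, first, only, none or still open, it means among the compounds named here.

Compound 1 `COc1cc(O)c(C(=O)O)c(C=Cc2ccc3ccccc3c2)c1` gives 65000 nM in an ADME assay on HEK293 cells (Homo sapiens) for cytotoxicity, read by resazurin assay, with a stated time of 24 h; on this read-out higher numbers stand for lower toxicity in this test and lower numbers for higher toxicity in this test.
Compound 2 `COc1cc(C=Cc2ccc3ccccc3c2)c(C(=O)O)c(OC)c1` gives > 100000 nM in this assay; this is a limit of the assay, not a number.
Compound 3 `Oc1cc(CCc2ccccc2)cc(O)c1O` gives 106000 nM in this assay.

Compound 2 stands at the edge of what the assay reports: the limit of > 100000 nM in this assay, at which 1 of the 3 values shown sits, so only a floor is known for it. Compound 4 `COc1cc(C)cc(C=Cc2ccc3ccccc3c2)c1C(=O)O` differs from compound 2 by methyl in place of methoxy on an aromatic carbon. For the measured compounds named here, the single measured step, an at least 1.5-fold higher number from compound 1 to compound 2 (0.18 log units; that floor lies within the scatter), involves a change on an oxygen rather than the replacement of a whole methoxy by methyl, so it speaks to the present change only indirectly, and its size lies within the scatter. In this assay no step beyond the scatter is therefore expected; the estimated step is a number no higher from compound 2 to compound 4 (the limit leaves the size open). Compound 4 is expected to give about 100000 nM, with a range from 50000 nM to 200000 nM, quite possibly again reported only as a limit.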

Compound 4, half-maximal cytotoxic concentration: 119000 nM
Estimate against measurement, compound 4: 1.2-fold (0.08 log units) below, within the range that was stated.
By their numbers in this assay, from the lowest: compounds 1, 3 and 4 (each within the scatter of the next).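

For the compounds shown here, no step from compound 2 to compound 4 can be read, because compound 2 carries a limit and not a number: the limit of > 100000 nM in this assay, at which 1 of the 4 values shown sits.
How far methyl in place of methoxy on an aromatic carbon moves the number in this assay stays open among the compounds shown.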